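Replacing 2-methylpyridin-3-yl on the shared core

The source may hold more compounds than are shown below. What is called first, only, known or untested is meant among the compounds shown, and "the series" means these compounds.

In a physicochemical assay for solubility, read by LC-MS, in phosphate buffer, with a stated time of 24 h, at pH 7.4 (on this read-out higher numbers stand for higher solubility and lower numbers for lower solubility), compound 1 `Cn1nccc1-c1cnc(NCc2c(F)ccc3c2CCO3)c2cn[nH]c(=O)c12` gives 2000 nM as a measured number. As far as these compounds go, compound 2 `Cc1ncccc1-c1cnc(NCc2c(F)ccc3c2CCO3)c2cn[nH]c(=O)c12` gives < 2000 nM as a limit of the assay and not a number, so its exact standing stays open. The change to compound 3 `CNC(=O)c1cc(-c2cnc(NCc3c(F)ccc4c3CCO4)c3cn[nH]c(=O)c23)n(C)n1` is 1-methyl-3-(methylcarbamoyl)-1H-pyrazol-5-yl in place of 2-methylpyridin-3-yl on an aromatic carbon on the same aromatic carbon of the shared core. Within the data shown here, the only measured step that bears on this change is a number no higher from compound 1 to compound 2 (the limit leaves the size open) and its size cannot be read. The low end of the scale is also poorly resolved, with the limit of < 2000 nM in this assay, at which 1 of the 2 values shown sits, to be kept in view. Among the measured compounds shown here, no step of known size can therefore be carried over, and compound 1 at 2000 nM is the only numeric anchor. The estimated step of an at least 1.2-fold higher number from compound 2 to compound 3 (0.09 log units; that floor lies within the scatter) is expected to be upward and modest, though the result may again arrive only as a limit. The expected value for compound 3 is 2500 nM within an estimated range of 1200 nM to 8000 nM in this assay as the read-out.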

Compound 3, solubility: 7000 nM
Compound 3: middle estimate off by 2.8-fold (0.45 log units), on the low side; low and high end bracket the measured number.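

In this assay, this position now has a step of readable size: on the 1-methyl-1H-pyrazol-5-yl group, methylcarbamoyl in place of hydrogen gives a 3.5-fold higher number from compound 1 to compound 3 (0.54 log units; beyond the scatter). The change from 2-methylpyridin-3-yl to 1-methyl-3-(methylcarbamoyl)-1H-pyrazol-5-yl gives an at least 3.5-fold higher number from compound 2 to compound 3 (0.54 log units; beyond the scatter), so a substituent on the pyrazole moves the read-out beyond the scatter. Compound 2 carries a limit and not a number, so that step is only a floor and the step into compound 2 cannot be read because of this limit: the limit of < 2000 nM in this assay, at which 1 of the 3 values shown sits.

Open, as far as these compounds go, is whether a carboxylic acid or a dimethylamide in place of methylcarbamoyl would give a step of similar size. Also open, from the compounds shown here alone, is whether methylcarbamoyl on the 2-methylpyridin-3-yl ring would raise the read-out as it does on the pyrazole.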